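This account rests on a few compounds, and the source may have more. Where it says the series, first, only, none or still open, it means among the compounds named here.

Measured compounds in this study:
- compound 1 `CCCCCCCCOc1nc(N)nc2c1ncn2/C=C1/CC1(CO)CO`: > 300000 nM
- compound 2 `Nc1nc(NC2CC2)c2ncn(/C=C3/CC3(CO)CO)c2n1`: > 300000 nM

In an ADME assay on HFF cells (Homo sapiens) for cytotoxicity, with a stated time of 8 days (on this read-out lower numbers stand for higher toxicity in this test and higher numbers for lower toxicity in this test), compound 1 gives > 300000 nM, which is a limit of the assay rather than a number. Compound 2 likewise gives > 300000 nM in this assay, again a limit and not a number. Within the data shown here, the single measured step, a step that the two limits leave unreadable from compound 1 to compound 2, therefore cannot be read, and the whole picture is summed up by the limit of > 300000 nM in this assay, at which 2 of the 2 values shown sit. Compound 1 thus stands at the limit, with nothing to rank it against.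

Compound 3 `CCCCCOc1nc(N)nc2c1ncn2/C=C1/CC1(CO)CO` has not yet been tested. It differs from compound 1 by hydrogen in place of propyl on a saturated chain carbon, five bonds along the chain from an oxygen on an aromatic ring. Among the measured compounds shown here, only the step from compound 1 to compound 2 bears on this, and its size is unreadable, so no direction can be drawn from the data. Compound 3 is expected to show no readable change, a number no higher from compound 1 to compound 3 (the limit leaves the size open), and to return another limit in this assay. The value of compound 3 is estimated at 300000 nM, within 100000 nM to 1000000 nM.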

Compound 3, half-maximal cytotoxic concentration: 259000 nM
Compound 3: middle estimate off by 1.2-fold (0.06 log units), on the high side, and the stated range covers the measured number.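

In this assay, among these compounds, compound 3 gives 259000 nM, the only value in the set that is a number and not a limit. Hydrogen in place of propyl, on a saturated chain carbon five bonds along the chain from an oxygen on an aromatic ring, gives an at least 1.1-fold lower number from compound 1 to compound 3 (0.06 log units; that floor lies within the scatter), and pentyloxy in place of cyclopropylamino on an aromatic carbon gives an at least 1.1-fold lower number from compound 2 to compound 3 (0.06 log units; that floor lies within the scatter). Both steps are floors, so neither shows a change beyond the scatter, and the rest of the picture still rests on a limit: the limit of > 300000 nM in this assay, at which 2 of the 3 values shown sit.

From the compounds shown here alone, the step from compound 1 to compound 2 still cannot be read, and how far either compound lies past its limit stays open. Also open, going by these compounds, is whether a butyloxy, decyloxy or benzyloxy group in place of pentyloxy would give a readable number in this assay.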